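The source may hold more compounds than are shown below. What is called first, only, known or untested is meant among the compounds shown, and "the series" means these compounds.

Measured so far in an assay on cells for agonist activity at ecdysone receptor (Bombyx mori), read by a luciferase reporter, with a stated time of 24 h; on this read-out lower numbers stand for an effect already at smaller amounts and higher numbers for an effect only at larger amounts of compound:
compound 1, `Cc1ccccc1C(=O)N(NC(=O)c1ccccc1)C(C)(C)C`, 224 nM
compound 2, `COc1ccccc1C(=O)N(NC(=O)c1ccccc1)C(C)(C)C`, 525 nM
compound 3, `Cc1cccc(C(=O)NN(C(=O)c2ccccc2Cl)C(C)(C)C)c1`, 603 nM

Compound 1 and compound 2 share one core and differ only by methoxy in place of methyl on an aromatic carbon. In this assay this gave a 2.3-fold higher number from compound 1 to compound 2 (0.37 log units; beyond the scatter). Compound 3 carries a different core; the difference between the core of compound 1 and the core of compound 3 is not broken down here. Compound 3 gives a higher number than compound 1 in this assay, beyond the scatter, while its number and that of compound 2 lie within the scatter of each other.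

Compound 4, `COc1cccc(C(=O)NN(C(=O)c2ccccc2Cl)C(C)(C)C)c1`, is not yet measured. It differs from compound 3 by methoxy in place of methyl on an aromatic carbon. The change is of the same kind as that from compound 1 to compound 2, but not the same: in compound 1 the methyl sits ortho to a large group, in compound 3 it sits meta to a large group, and the two cores are not the same.

Among the compounds with values here, only one measured instance of the change exists, so the expectation rests on it alone. The step from compound 3 to compound 4 in this assay is estimated as a 2.2-fold higher number from compound 3 to compound 4 (0.33 log units; beyond the scatter), set beside a 2.3-fold higher number from compound 1 to compound 2 (0.37 log units; beyond the scatter), with a wide range because the place of the change and the core both differ and because compound 3 already stands at 603 nM. Compound 4 is accordingly expected to give about 1300 nM in this assay, estimated between 600 nM and 3000 nM.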

Compound 4, half-maximal effective concentration: 52.5 nM
Compound 4: middle estimate off by 25-fold (1.39 log units), on the high side; the measured number lies below the stated range.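

In this assay, methoxy in place of methyl on an aromatic carbon, meta to a large group, gave an 11-fold lower number from compound 3 to compound 4 (1.06 log units; beyond the scatter), so this change lowers the number on this core. Set beside the earlier step, the same change does not carry over from one core to the other in either direction or size: the same change on two cores in this assay, a 2.3-fold higher number (0.37 log units; beyond the scatter) from compound 1 to compound 2 and an 11-fold lower number (1.06 log units; beyond the scatter) from compound 3 to compound 4, 27-fold (1.43 log units) apart, beyond the scatter of two such steps The two steps show that the result for this change on one core cannot be used as an estimate for the other, but they do not show whether the gap follows from the place of the change on the aromatic ring, from the rest of the core, or from both, as the two pairs differ in both respects and each pair stands alone.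

Still open, going by these compounds, is how a 3-methylphenyl to 3-methoxyphenyl change would behave on the core of compound 1, a comparison that would hold the place of the change constant while the core differs. Also open, on these data alone, is whether an ethoxy group, a hydroxyl group or an amine at the same place would give a number closer to that of compound 4 or that of compound 3.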